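The source may hold more compounds than are shown below. What is called first, only, known or untested is meant among the compounds shown, and "the series" means these compounds.

Within the data shown here, in a functional assay on L1210 cells (Mus musculus) for inhibition, read by cell counting, with a stated time of 2 days (on this read-out lower numbers stand for stronger inhibition and higher numbers for weaker inhibition), compound 2 `COc1ccc(Cc2nn3cc(-c4cccc(N)c4)nc3s2)cc1` gives 227000 nM, the highest of the two numbers measured so far, while compound 1 `C=C(Br)C(=O)Nc1cccc(-c2cn3nc(-c4ccc(F)cc4)sc3n2)c1` gives 250 nM, a far lower number that lies beyond the usual scatter. Compound 3 `C=C(Br)C(=O)Nc1cccc(-c2cn3nc(Cc4ccc(OC)cc4)sc3n2)c1` has not yet been measured. It differs from compound 2 in one place: (1-bromoethenyl)carbonyl in place of hydrogen on a nitrogen on an aromatic ring. Among the measured compounds shown here, compound 1 carries this same group but differs from compound 2 elsewhere too, so no single step isolates it. Still, a large step toward a lower number is expected, a 230-fold lower number from compound 2 to compound 3 (2.36 log units; beyond the scatter). Compound 3 is estimated at 1000 nM, within a range from 150 nM to 8000 nM.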

Compound 3, half-maximal inhibitory concentration: 1400 nM
For compound 3 the middle estimate is 1.4-fold (0.15 log units) below the measured one; the measured number falls inside the stated range.
By their numbers in this assay, from the lowest: compound 1; then compound 3; then compound 2.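

In this assay, changing amino to ((1-bromoethenyl)carbonyl)amino on the aromatic ring gives a 160-fold lower number from compound 2 to compound 3 (2.21 log units; beyond the scatter), so this one change alone produces a large step, which compound 1 could not isolate. Putting 4-methoxybenzyl in place of 4-fluorophenyl on an aromatic carbon gives a 5.6-fold higher number from compound 1 to compound 3 (0.75 log units; beyond the scatter), a modest step by comparison. Nothing measured here explains either step.

Going by these compounds, it remains open whether an acetyl group on that nitrogen, or chlorine in place of the bromine, would give a similar number. On these data alone, it is also open whether the amide step would be the same size with the 4-fluorophenyl group present.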